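The source may hold more compounds than are shown below. What is called first, only, known or untested is meant among the compounds shown, and "the series" means these compounds.

The measured compounds and their numbers:

Compound 1 `Fc1cc(Cl)ccc1-c1ccc(Cn2nnc3ccccc32)cn1`: 50 nM
Compound 2 `Brc1cccc2c1nnn2CC1CCCCC1`: 10 nM
Compound 3 `Brc1cccc2c1nnn2CC1CCCC1`: 30 nM

Of the compounds shown here, three have been measured in a functional assay on cells for positive allosteric modulation of metabotropic glutamate receptor 2 (Homo sapiens), read by fluorescence and calcium flux, with a stated time of 30 min; a lower number here means that less compound is needed, a higher number that more compound is needed for the effect. Compound 3 gives 30 nM and stands second highest of the three numbers. Its nearest neighbour is compound 1, which in this assay gives 50 nM, a gap that lies within the scatter, so no order between compound 3 and compound 1 can be read from these two numbers. The furthest is compound 2, which gives 10 nM, a gap that lies beyond the scatter; compound 2 therefore needs less compound for the effect than compound 3.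

The next compound, compound 4 `Cn1nnc2c(Br)cccc21`, has not yet been measured. It differs from compound 3 in one place: hydrogen in place of cyclopentyl on a saturated chain carbon bound to an aromatic nitrogen. The saturated chain carbon bound to an aromatic nitrogen now carries only hydrogens, so the cyclopentyl of compound 3 is gone without replacement. No step of this kind has been measured among the shown compounds, so the expectation rests on what is at hand: compound 2 with cyclohexyl gives 10 nM and compound 3 with cyclopentyl gives 30 nM, and removing the ring altogether is expected to move the number further upward, by a step of a 33-fold higher number from compound 3 to compound 4 (1.52 log units; beyond the scatter) that is expected to lie well beyond the scatter. Compound 4 is accordingly estimated at 1000 nM, with a range from 200 nM to 5000 nM.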

Compound 4, half-maximal effective concentration: > 5000 nM
Compound 4: only a limit was reported; the forecaster's own chance of this, stated with the estimate: 25%; at least 5.0-fold (0.69 log units) between middle value and limit.
By their numbers in this assay, from the lowest: compound 2; then compounds 3 and 1 (each within the scatter of the next). At a limit, above all of these: compound 4.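

In this assay the result for compound 4 is a limit and not a number: the limit of > 5000 nM in this assay, at which 1 of the 4 values shown sits. Even read against that limit, putting hydrogen in place of cyclopentyl on the saturated chain carbon bound to an aromatic nitrogen gives an at least 160-fold higher number from compound 3 to compound 4 (2.22 log units; beyond the scatter), a large step and the first single change in the series whose size can be read. The earlier compounds shown here all carry a ring on this carbon, so they could not show what happens without one; this result shows that the position is highly sensitive to losing the cyclopentyl group, with its one five-membered ring of carbon only.

The limit leaves the true size of the step open, so it cannot be said how far compound 4 lies from the other compounds. The compounds shown also leave open how much of the cyclopentyl group this place requires, and whether an open chain such as ethyl or n-butyl, or a ring carrying an amine or a carboxylic acid, would keep the number close to that of compound 3.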